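Nitrobenzimidazole thioethers: cytotoxicity notes on compounds 2 and 4

The source may hold more compounds than are shown below. What is called first, only, known or untested is meant among the compounds shown, and "the series" means these compounds.

Measured so far in a functional assay on HepG2 cells (Homo sapiens) for cytotoxicity, read by MTT assay, with a stated time of 48 h; on this read-out higher numbers stand for weaker inhibition and lower numbers for stronger inhibition:
compound 1 `O=[N+]([O-])c1ccc2[nH]c(CSCc3nc4cc([N+](=O)[O-])ccc4[nH]3)nc2c1` gives 2250 nM
compound 2 `O=C(CSCc1nc2cc([N+](=O)[O-])ccc2[nH]1)c1ccc(Br)cc1` gives 2010 nM
compound 3 `O=C(CSCc1nc2cc([N+](=O)[O-])ccc2[nH]1)N/N=C/c1ccc(Cl)cc1` gives 56800 nM

Compound 2 gives the lowest of the three numbers in this assay. Compound 1 sits within the scatter of compound 2, so no order between the two can be read. Compound 3 lies beyond the scatter on the high side, the only clear separation in the set. All three share the nitrobenzimidazole thioether portion; they differ in what hangs on the far side of the sulfur.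

Compound 4 `CC1=NN(C(=O)CSCc2nc3cc([N+](=O)[O-])ccc3[nH]2)C(=O)C1` has not been measured. It differs from compound 2 by a group of 7 heavy atoms (4 carbon, 2 nitrogen, 1 oxygen; one five-membered non-aromatic ring with 2 hetero atoms) in place of a group of 7 heavy atoms (6 carbon, 1 bromine; one six-membered aromatic ring of carbon only), on a carbonyl carbon. Going by the values given here, no directly measured step of this kind exists in the set, so the expectation rests on the pattern that the aryl ketone in compound 2 and the bis-benzimidazole in compound 1 give the low numbers, while the acylhydrazone carbonyl in compound 3 gives a far higher one.

The change in compound 4 moves the carbonyl toward a nitrogen-linked, non-aromatic partner, closer in character to compound 3 than to compound 2. The expected step of a 7.5-fold higher number from compound 2 to compound 4 (0.87 log units; beyond the scatter) is therefore upward and beyond the scatter, though likely not reaching the number of compound 3 because compound 3 gives 56800 nM with a longer hydrazone linker. Compound 4 is estimated at 15000 nM, with a range from 3000 nM to 60000 nM.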

Compound 4, half-maximal inhibitory concentration: 7330 nM
Estimate against measurement, compound 4: 2.0-fold (0.31 log units) above; measured number inside the range.
By their numbers in this assay, from the lowest: compounds 2 and 1 (each within the scatter of the next); then compound 4; then compound 3.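

In this assay, going by these compounds alone, putting the five-membered non-aromatic ring with 2 hetero atoms in place of 4-bromophenyl on the carbonyl carbon gives a 3.6-fold higher number from compound 2 to compound 4 (0.56 log units; beyond the scatter) and is the only directly measured step, so this position now has a measured response to a change of group. The two groups have the same count of 7 heavy atoms, so the step comes without a change in that count; it goes with the loss of the bromine and the aromatic ring and the gain of 2 hydrogen-bond acceptors. Nothing measured here accounts for the size or direction of this step.

Within the data shown here, the single step changes several features at once and leaves open which of them goes with the higher number. A plain phenyl on the same carbonyl carbon would separate the bromine from the aromatic ring, while a piperidine amide there would test a nitrogen-linked saturated ring without the ring carbonyl or the ring double bond of compound 4.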